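This account rests on a few compounds, and the source may have more. Where it says the series, first, only, none or still open, it means among the compounds named here.

Compound 2 `N=c1ccn([C@H]2C[C@H](O)[C@@H](CO)O2)c(=O)n1N` gives 2000 ug/mL in a functional assay on L1210 cells (Mus musculus) for inhibition (on this read-out higher numbers stand for weaker inhibition and lower numbers for stronger inhibition), the higher of the two numbers at hand; compound 1 `N=c1ccn([C@@H]2O[C@H](CO)[C@@H](O)[C@H]2O)c(=O)n1N` gives 400 ug/mL in this assay. Within the data shown here, the one step that bears on the change is a 5.0-fold higher number from compound 1 to compound 2 (0.70 log units; beyond the scatter), the reverse of what is now done. Compound 3 `N=c1ccn([C@@H]2O[C@H](CO)[C@@H](O)[C@@H]2O)c(=O)n1N` carries hydroxy in place of hydrogen on a saturated ring carbon. Among the measured compounds shown here, the only difference from compound 1 is the arrangement at that ring carbon. The step is expected to run toward a lower number, about a 6.7-fold lower number from compound 2 to compound 3 (0.82 log units; beyond the scatter), because of a 5.0-fold higher number from compound 1 to compound 2 (0.70 log units; beyond the scatter). Compound 3 is thus estimated at 300 ug/mL, with a range from 60 ug/mL to 1500 ug/mL.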

Compound 3, half-maximal inhibitory concentration: 45 ug/mL
For compound 3 the middle estimate is 6.7-fold (0.82 log units) above the measured one, and the stated range ends above it.
By their numbers in this assay, from the lowest: compound 3; then compound 1; then compound 2.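

Hydroxy in place of hydrogen on this saturated ring carbon gives a 44-fold lower number from compound 2 to compound 3 (1.65 log units; beyond the scatter), so what the hydroxy group brings depends on its arrangement, which compound 1 alone could not show. With atoms and bonds unchanged, the arrangement by itself gives an 8.9-fold lower number from compound 1 to compound 3 (0.95 log units; beyond the scatter). In this assay, the configuration at this ring carbon therefore counts as a variable of its own: the fact that one of compounds 1 and 3 is drawn with a defined configuration and the other without, at the place where they differ

From the compounds shown here alone, an amine or a methoxy group on this ring carbon, in either arrangement, remains open. So does whether arrangement matters equally at the ring atom that bears the hydroxymethyl group.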